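From pyridin-2-yl to 4-chlorophenyl on the shared core

This account rests on a few compounds, and the source may have more. Where it says the series, first, only, none or still open, it means among the compounds named here.

Of the compounds shown here, three have been measured in a functional assay on A549 cells (Homo sapiens) for cytotoxicity, read by resazurin assay, with a stated time of 72 h; on this read-out lower numbers stand for stronger inhibition and higher numbers for weaker inhibition. Compound 1 `N#Cc1cc(-c2ccccc2)n(-c2ccccn2)c1N` gives 32000 nM, compound 2 `N#Cc1cc(-c2ccccc2)n(Cc2nc3ccccc3[nH]2)c1N` gives 12000 nM and compound 3 `Nc1c(-c2nc3ccccc3[nH]2)cc(-c2ccccc2)n1-c1ccccn1` gives 8000 nM. Compound 3 and compound 2 lie within the scatter of each other, while compound 1 stands beyond the scatter from compound 3, with the higher number.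

Compound 4 `Nc1c(-c2nc3ccccc3[nH]2)cc(-c2ccccc2)n1-c1ccc(Cl)cc1` carries one change from compound 3: 4-chlorophenyl in place of pyridin-2-yl on an aromatic nitrogen. Among the measured compounds shown here, no measured step isolates a change at that nitrogen. For the measured compounds named here, the only measured step, a 4.0-fold lower number from compound 1 to compound 3 (0.60 log units; beyond the scatter), is modest and comes from 1H-benzimidazol-2-yl in place of cyano on an aromatic carbon. It therefore bears on this change only indirectly, as a guide to how large a single change has been among these compounds.

In this assay, a step no larger than that one is expected, leaning slightly towards a lower number and quite possibly staying within the scatter. The expected step is a 1.6-fold lower number from compound 3 to compound 4 (0.20 log units; within the scatter). Compound 4 is estimated at 5000 nM, with an expected range from 1500 nM to 16000 nM.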

Compound 4, half-maximal inhibitory concentration: 9900 nM
Beside the measured number, compound 4's estimate is 2.0-fold (0.30 log units) below it, and the stated range covers the measured number.
By their numbers in this assay, from the lowest: compounds 3, 4 and 2 (each within the scatter of the next); then compound 1.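

In this assay, among the compounds shown here, the first measured change at the aromatic nitrogen of the shared core gives a 1.2-fold higher number from compound 3 to compound 4 (0.09 log units; within the scatter) and so stays within the scatter. With the 1H-benzimidazol-2-yl group in place, this read-out therefore does not separate pyridin-2-yl, with its ring nitrogen and hydrogen-bond acceptor, from 4-chlorophenyl, with its all-carbon ring and chlorine. Nothing available here offers an explanation for this result.

The compounds shown leave open whether the same exchange would also stay within the scatter with the nitrile of compound 1 on the aromatic carbon instead of the 1H-benzimidazol-2-yl group. They also leave open whether a group of a different kind on this nitrogen, such as a simple methyl, a longer alkyl chain ending in an amine, or a benzyl group carrying a carboxylic acid, would move the number beyond the scatter.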